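This account rests on a few compounds, and the source may have more. Where it says the series, first, only, none or still open, it means among the compounds named here.

In a functional assay on HL-60 cells (Homo sapiens) for cytotoxicity, read by WST assay, with a stated time of 48 h (on this read-out higher numbers stand for an effect only at larger amounts of compound and lower numbers for an effect already at smaller amounts), compound 1 `O=C1OC[C@H](Cc2ccccc2)[C@H]1Cc1ccccc1OC(F)(F)F` gives 39000 nM while compound 2 `CCCCCCCOc1ccccc1C[C@H]1C(=O)OC[C@@H]1Cc1ccccc1` gives 75000 nM and compound 3 `Cc1ccccc1C[C@H]1C(=O)OC[C@@H]1Cc1ccccc1` gives 57000 nM in a set whose three values all lie within the scatter of one another. Compound 4 `O=C1OC[C@H](Cc2ccccc2)[C@H]1Cc1ccccc1C(F)(F)F` carries trifluoromethyl in place of methyl on an aromatic carbon, ortho to a large group. Among the compounds with values here, no measured step makes this exact exchange, but three measured steps bear on it, namely a 1.5-fold higher number from compound 1 to compound 3 (0.16 log units; within the scatter) together with a 1.3-fold lower number from compound 2 to compound 3 (0.12 log units; within the scatter) and a 1.9-fold higher number from compound 1 to compound 2 (0.28 log units; within the scatter) and none of them leaves the scatter. No step beyond the scatter is therefore expected in this assay for this exchange. The expected step is small (a 1.1-fold lower number from compound 3 to compound 4 (0.06 log units; within the scatter)). Compound 4 is estimated at 50000 nM (expected range 25000 nM to 95000 nM).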

Compound 4, half-maximal effective concentration: 37000 nM
Beside the measured number, compound 4's estimate is 1.4-fold (0.13 log units) above it; low and high end bracket the measured number.
By their numbers in this assay, from the lowest: compounds 4, 1, 3 and 2 (each within the scatter of the next, the first and the last beyond it).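

In this assay, trifluoromethyl on this aromatic carbon, ortho to a large group, yields the only step among these compounds that lies beyond the scatter, and a modest one (a 2.0-fold lower number from compound 2 to compound 4 (0.31 log units; beyond the scatter)), against heptyloxy. Against the other two groups it stays within the scatter, whether against methyl (a 1.5-fold lower number from compound 3 to compound 4 (0.19 log units; within the scatter)) or trifluoromethoxy (a 1.1-fold lower number from compound 1 to compound 4 (0.02 log units; within the scatter)), so the exchange of methyl for trifluoromethyl shows no clear change here. Nothing measured here accounts for these numbers. The compounds shown leave open whether an amine or a carboxylic acid on this carbon would move the number further. They also leave open whether trifluoromethyl would behave alike on another carbon of this ring.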